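A few compounds are considered here, and "the series" means these few. Any claim that something is new, unique, unknown or untested is made for them only; others in the source may bear on it.

Measured compounds:
compound 1, `NC(=O)c1c(NC(=O)c2ccc(C(F)(F)F)cc2)sc2c1CCN(C(=O)Nc1ccccc1Cl)C2`: > 50000 nM
compound 2, `Cc1ccc(C(=O)Nc2sc3c(c2C(N)=O)CCN(C(=S)Nc2ccccc2Cl)C3)cc1`: 26300 nM

Both were tested in a functional assay on HeLa cells (Homo sapiens) for antiproliferative activity, with a stated time of 24 h; on this read-out lower numbers stand for stronger inhibition and higher numbers for weaker inhibition. For compound 1 the result in this assay is a limit of the assay, > 50000 nM, not a measured number. For the measured compounds named here, compound 2 gives 26300 nM in this assay, the only real number among the two; the other value sits at the limit of > 50000 nM in this assay, at which 1 of the 2 values shown sits. So compound 2 is itself a weak inhibitor, and nothing here shows a compound doing better.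

Compound 3, `Cc1ccc(C(=O)Nc2sc3c(c2C(N)=O)CCN(C(=O)Nc2ccccc2Cl)C3)cc1`, is not yet measured. It differs from compound 2 in one place: a group of 10 heavy atoms (7 carbon, 1 nitrogen, 1 oxygen, 1 chlorine; one six-membered aromatic ring of carbon only) in place of a group of 10 heavy atoms (7 carbon, 1 nitrogen, 1 sulfur, 1 chlorine; one six-membered aromatic ring of carbon only), on an amine nitrogen in a ring. Going by the values given here, no step between two measured compounds is available to gauge this change, so the expectation rests on the two values alone. Compound 1, which carries the same (2-chlorophenyl)carbamoyl group, only reached a limit, > 50000 nM.

Compound 3 is therefore expected to be a little weaker than compound 2, with a step of a 1.7-fold higher number from compound 2 to compound 3 (0.23 log units; within the scatter) toward weaker inhibition. The estimate for compound 3 is 45000 nM, with a range from 15000 nM to 150000 nM, and a fair chance that the assay again reports only a limit.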

Compound 3, half-maximal inhibitory concentration: 32900 nM
Compound 3: the middle estimate sits 1.4-fold (0.14 log units) above what was measured, within the range that was stated.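

Exchanging the sulfur of compound 2 for the oxygen of the (2-chlorophenyl)carbamoyl group, on an amine nitrogen in a ring, leaves the two compounds indistinguishable in this assay, with a 1.3-fold higher number from compound 2 to compound 3 (0.10 log units; within the scatter), so this single-atom change has no visible effect on this read-out. The second comparison, methyl in place of trifluoromethyl on an aromatic carbon, gives an at least 1.5-fold lower number from compound 1 to compound 3 (0.18 log units; that floor lies within the scatter), and this too does not establish a real difference. That step is only a floor, and the true gap could be larger, because the value of compound 1 is a limit and not a number: the limit of > 50000 nM in this assay, at which 1 of the 3 values shown sits.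

From the compounds shown here alone, it remains open whether a different group on this amine nitrogen, such as a benzoyl group or a longer alkyl chain, would give much stronger inhibition. The same question stands for an amine or a carboxylic acid in place of the methyl on the aromatic carbon.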